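A few compounds are considered here, and "the series" means these few. Any claim that something is new, unique, unknown or untested is made for them only; others in the source may bear on it.

Compound 1 `COc1cc2nc(N3CCN(C(=O)c4ccc(C(C)(C)C)cc4)CC3)nc(N)c2cc1OC`: 47000 nM
Compound 2 `COc1cc2nc(N3CCN(C(=O)c4ccc(C(F)(F)F)cc4)CC3)nc(N)c2cc1OC`: limit only, > 100000 nM
Compound 3 `COc1cc2nc(N3CCN(S(=O)(=O)c4ccc(Cl)cc4)CC3)nc(N)c2cc1OC`: 23000 nM

In a functional assay on PC-3 cells (Homo sapiens) for inhibition (a higher number here means a weaker inhibitor, a lower number a stronger inhibitor), compound 1 gives 47000 nM and compound 3 gives 23000 nM, the lowest of the two numbers, with compound 1 as the nearest. For compound 2 the assay reports only a limit, > 100000 nM; this is the limit of > 100000 nM in this assay, at which 1 of the 3 values shown sits. Going by the values given here, the single measured step is an at least 2.1-fold higher number from compound 1 to compound 2 (0.32 log units; beyond the scatter), an exchange of one group for another on an aromatic carbon, which does not touch the change now in hand. Compound 4 `COc1cc2nc(N3CCN(S(=O)(=O)c4ccc(-c5ccc(C(C)(C)C)cc5)cc4)CC3)nc(N)c2cc1OC` differs from compound 3 by 4-(tert-butyl)phenyl in place of chloro on an aromatic carbon. Among the compounds with values here, no measured step covers this kind of enlargement, so no direction beyond the scatter is expected, and the uncertainty is wide. For compound 4 the expected value is 20000 nM, with a range of 5000 nM to 100000 nM. The step expected is a 1.2-fold lower number from compound 3 to compound 4 (0.06 log units; within the scatter).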

Compound 4, half-maximal inhibitory concentration: 10000 nM
Compound 4: middle estimate off by 2.0-fold (0.30 log units), on the high side; the range from low to high includes it.
By their numbers in this assay, from the lowest: compound 4; then compound 3; then compound 1. At a limit, above all of these: compound 2.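

In this assay the aromatic carbon that carried chloro accepts the far larger 4-(tert-butyl)phenyl with no loss, the change giving a 2.3-fold lower number from compound 3 to compound 4 (0.36 log units; beyond the scatter). Going by these compounds alone, the earlier step exchanged only one group for another on an aromatic carbon, so this is the first sign that an added aromatic ring is compatible with this read-out here. No measurement shown accounts for the step. Open, on these data alone, is whether plain phenyl, or an amine or carboxylic acid on the added ring, would hold this level.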